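Exchanging an oxazole for a carboxyphenyl on the shared core

A few compounds are considered here, and "the series" means these few. Any claim that something is new, unique, unknown or untested is made for them only; others in the source may bear on it.

Compound 1 `N#CCCCn1c(Cn2c(=O)n(-c3ncco3)c3ccncc32)cc2cc(Cl)ccc21` was tested in an ADME assay on HeLa cells (Homo sapiens) for cytotoxicity, read by ATP content, with a stated time of 3 days (on this read-out lower numbers stand for higher toxicity in this test and higher numbers for lower toxicity in this test), and gives > 50000 nM, which is a limit of the assay rather than a number. Compound 2 `O=c1n(Cc2nc3nc(Cl)ccc3n2CCCCO)c2cnccc2n1C1CC1` likewise gives > 50000 nM, a limit. Compound 3 `O=c1n(Cc2nc3ncccc3n2CCCCO)c2cnccc2n1C1CC1` gives > 100000 nM, also a limit. Among the measured compounds shown here, the one comparable step, a step that the two limits leave unreadable from compound 2 to compound 3, therefore cannot be sized. For the measured compounds named here, every value stands at a limit, as the limit of > 100000 nM in this assay, at which 1 of the 3 values shown sits, and the limit of > 50000 nM in this assay, at which 2 of the 3 values shown sit, show, so no measured step bears on the change toward compound 4 `N#CCCCn1c(Cn2c(=O)n(-c3ccc(C(=O)O)cc3)c3ccncc32)cc2cc(Cl)ccc21`, namely (4-carboxyphenyl in place of 1,3-oxazol-2-yl on an aromatic nitrogen). With no readable step in this assay, no change beyond the scatter is expected from compound 1 to compound 4. Compound 4 is estimated at 60000 nM, between 30000 nM and 150000 nM, a step that the limit leaves unreadable from compound 1 to compound 4 that is expected to remain at the limit.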

Compound 4, half-maximal cytotoxic concentration: > 50000 nM
Compound 4: only a limit was reported; the forecaster's own chance of this, stated with the estimate: 80%; the middle value lies beyond the limit too.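

Among the compounds shown here, compound 1 and compound 4 both stand at a limit in this assay, not at a number, and no step between them can be read. The compounds shown leave open whether any change on the shared core shifts this read-out at all.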